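Working notes: from compound 3 to compound 4

A few compounds are considered here, and "the series" means these few. Any claim that something is new, unique, unknown or untested is made for them only; others in the source may bear on it.

Values in a functional assay on MCF7 cells (Homo sapiens) for antiproliferative activity, read by sulforhodamine B assay, with a stated time of 48 h; on this read-out lower numbers stand for stronger inhibition and higher numbers for weaker inhibition:
- compound 1 `CCCCN1CCN(c2ccc(S(=O)(=O)Oc3ccccc3)cc2)C1=O` gives 8800 nM
- compound 2 `CCCCN1CCN(c2ccc(S(=O)(=O)Oc3ccccc3OC)cc2)C1=O` gives 3800 nM
- compound 3 `CCCCN1CCN(c2ccc(S(=O)(=O)Oc3cccc(Br)c3)cc2)C1=O` gives 85 nM

Compound 3 stands lowest of the three numbers, well clear of the other two. Compound 4 `CCCCN1CCN(c2ccc(S(=O)(=O)Oc3ccc(F)c(F)c3)cc2)C1=O` is not yet measured. It carries 3,4-difluorophenyl in place of 3-bromophenyl on an oxygen.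

Among the compounds with values here, no measured compound carries fluorine, so this swap has no direct precedent. The nearest evidence is indirect. Bromo in place of hydrogen on an aromatic carbon gave a 100-fold lower number from compound 1 to compound 3 (2.02 log units; beyond the scatter), whereas methoxy in place of hydrogen gave only a 2.3-fold lower number from compound 1 to compound 2 (0.36 log units; beyond the scatter). Exchanging the aryl groups of the two substituted compounds gave a 45-fold lower number from compound 2 to compound 3 (1.65 log units; beyond the scatter), so the number has moved strongly with the identity of the substituent. Compound 4 no longer has the bromo group, and a clear move back toward compound 1 is therefore expected in this assay, though probably not all the way. The expected change is a 7.1-fold higher number from compound 3 to compound 4 (0.85 log units; beyond the scatter). For compound 4 the estimated value is 600 nM, with an expected range of 120 nM to 3000 nM.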

Compound 4, half-maximal inhibitory concentration: 760 nM
For compound 4 the middle estimate is 1.3-fold (0.10 log units) below the measured one; the range from low to high includes it.
By their numbers in this assay, from the lowest: compound 3; then compound 4; then compound 2; then compound 1.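

The 3,4-difluorophenyl group shows that an aryl group on this oxygen can keep much of the gain without bromine in this assay, with a 12-fold lower number from compound 1 to compound 4 (1.06 log units; beyond the scatter) and a 5.0-fold lower number from compound 2 to compound 4 (0.70 log units; beyond the scatter). The 3-bromophenyl group still gives the lowest number of the series, and replacing it costs a clear step, with an 8.9-fold higher number from compound 3 to compound 4 (0.95 log units; beyond the scatter). No measurement at hand accounts for the difference between these aryl groups.

From the compounds shown here alone, it remains open whether 3-fluorophenyl or 3-chlorophenyl would fall nearer the bromo or the difluoro compound, so the contribution of the halogen's identity cannot be separated from that of having one substituent rather than two. Also open, going by these compounds, is how the number responds to an amine or a carboxylic acid on this aryl group, or to a longer chain on the shared core.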